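Notes on the step from compound 2 to compound 3

The source may hold more compounds than are shown below. What is called first, only, known or untested is meant among the compounds shown, and "the series" means these compounds.

In a functional assay on HCT-116 cells (Homo sapiens) for antiproliferative activity, read by MTT assay, with a stated time of 24 h (on this read-out higher numbers stand for weaker inhibition and lower numbers for stronger inhibition), compound 1 `COc1ccc(C(=O)/C=C/c2cccc([N+](=O)[O-])c2)c2c1C=CC(C)(C)O2` gives 8050 nM. Compound 2 `COc1ccc(C(=O)/C=C/c2ccccc2Cl)c2c1C=CC(C)(C)O2` stands only at a limit of the assay, > 10000 nM, so it has no exact number. Compound 3 `COc1ccccc1/C=C/C(=O)c1ccc(OC)c2c1OC(C)(C)C=C2` has methoxy in place of chloro on an aromatic carbon, ortho to a large group, which reads as 2-chlorophenyl to 2-methoxyphenyl: methoxy in place of chloro on an aromatic carbon.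

Among the compounds with values here, only one measured step bears on this change: an at least 1.2-fold higher number from compound 1 to compound 2 (0.09 log units; that floor lies within the scatter). It also alters the substituted phenyl, but its floor lies within the scatter, so it sets no size for the new change. No shift beyond the scatter is therefore expected in this assay, in either direction. The expected step is an at least 1.1-fold lower number from compound 2 to compound 3 (0.04 log units; that floor lies within the scatter). Compound 3 is estimated at 9000 nM, with an expected range of 3500 nM to 20000 nM.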

Compound 3, half-maximal inhibitory concentration: > 10000 nM
Compound 3: a limit, no number; the forecaster's own chance of this, stated with the estimate: 50%; at least 1.1-fold (0.04 log units) between middle value and limit.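

In this assay, methoxy in place of chloro on an aromatic carbon, ortho to a large group, leaves compound 3 at the same limit of the assay as compound 2, so the step between them cannot be read: the limit of > 10000 nM in this assay, at which 2 of the 3 values shown sit.

Against compound 1, 2-methoxyphenyl in place of 3-nitrophenyl gives an at least 1.2-fold higher number from compound 1 to compound 3 (0.09 log units; that floor lies within the scatter), so this comparison sets no size for the change either. What compound 3 adds is a second ortho group, after chloro, that yields no exact number in this assay.

The compounds shown leave open whether any group at this place can bring a readable value. An amine there, as in a 2-aminophenyl, would test this, and the reading of both chloro and methoxy would still rest on limits alone.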